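The compounds below may be only part of what the source reports. "The series", "measured", "known", "first", "only" and "open" are said of these compounds alone.

Working notes on the series. Compound 1 `COc1ccc(-c2ssc(=O)c2-c2cc(OC)c(OC)c(OC)c2)cc1` in a functional assay on HT-1080 cells (Homo sapiens) for antiproliferative activity, read by MTT assay, with a stated time of 72 h (a higher number here means a weaker inhibitor, a lower number a stronger inhibitor), gives 464 nM. Compound 2 `COc1ccc(-c2ssc(=O)c2-c2cc(OC)c(OC)c(OC)c2)cc1[N+](=O)[O-]` differs from it by one change, (nitro in place of hydrogen on an aromatic carbon), and in this assay compound 2 gives 4220 nM; the resulting step is a 9.1-fold higher number from compound 1 to compound 2 (0.96 log units; beyond the scatter). Compound 3 `COc1ccc(-c2c(-c3cc(OC)c(OC)c(OC)c3)ss/c2=N/O)cc1` is built on a different core; the difference between the two cores is not broken down here. In this assay compound 3 reaches only a limit of the assay, > 100000 nM. Compound 4 `COc1ccc(-c2c(-c3cc(OC)c(OC)c(OC)c3)ss/c2=N/O)cc1[N+](=O)[O-]` has not yet been measured; it carries the change (nitro in place of hydrogen on an aromatic carbon), the same change as from compound 1 to compound 2, which thus occurs twice among these compounds, at a place described in the same words both times.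

For this assay the step from compound 3 to compound 4 is expected to be a step that the limit leaves unreadable from compound 3 to compound 4, because compound 3 already sits at the limit of > 100000 nM in this assay, at which 1 of the 3 values shown sits, and the earlier instance of the change gave a weaker inhibitor. Compound 4 is therefore estimated at about 400000 nM, between 100000 nM and 2000000 nM, most likely reported again only as a limit.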

Compound 4, half-maximal inhibitory concentration: 3030 nM
Compound 4: the middle estimate sits 130-fold (2.12 log units) above what was measured; the whole stated range lies above it.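

In this assay, nitro in place of hydrogen on an aromatic carbon now gives an at least 33-fold lower number from compound 3 to compound 4 (1.51 log units; beyond the scatter), opposite in direction to the earlier step on the other core, and the two steps differ: the same change on two cores in this assay, a 9.1-fold higher number (0.96 log units; beyond the scatter) from compound 1 to compound 2 and an at least 33-fold lower number (1.51 log units; beyond the scatter) from compound 3 to compound 4, at least 300-fold (2.47 log units) apart, beyond the scatter of two such steps

For compound 3, the value > 100000 nM is a limit of the assay and not a number, so the direction of the new step can be read but its full size cannot. The two pairs show that the outcome of this change does not carry from one core to the other in this series, but they do not show which difference between the cores goes with the reversal, or why it occurs.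

The compounds shown leave open whether an amine or a carboxylic acid in place of the nitro group would also give opposite steps on the two cores. They also leave open how the nitro change would behave on any third core.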